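A methyl on the amide-side ring: compound 1 to compound 4

The compounds below may be only part of what the source reports. "The series", "measured", "known", "first", "only" and "open" are said of these compounds alone.

Measured so far in a functional assay on HeLa cells (Homo sapiens) for inhibition, read by MTT assay, with a stated time of 48 h; on this read-out higher numbers stand for weaker inhibition and lower numbers for stronger inhibition:
compound 1 `COc1ccc2c(=O)c(/C=C/C(=O)Nc3ccccc3)coc2c1`: > 100000 nM, a limit of the assay
compound 2 `COc1ccc2c(=O)c(/C=C/C(=O)NCc3ccc(C)cc3)coc2c1`: > 100000 nM, a limit of the assay
compound 3 `O=C(/C=C/c1coc2cc(O)ccc2c1=O)Nc1ccccc1`: 9700 nM

Compound 1 stands at the limit of this assay; no number is known for it. Compound 2 sits at the same limit, so the step that the two limits leave unreadable from compound 1 to compound 2 cannot be read. The step of an at least 10-fold lower number from compound 1 to compound 3 (1.01 log units; beyond the scatter) is the only readable one, and it concerns the oxygen on the aromatic ring, not the amide side.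

Compound 4 `COc1ccc2c(=O)c(/C=C/C(=O)Nc3cccc(C)c3)coc2c1` differs from compound 1 by methyl in place of hydrogen on an aromatic carbon. Going by the values given here, no measured step touches that position; the one change on the amide side, a step that the two limits leave unreadable from compound 1 to compound 2, is unreadable. With the limit of > 100000 nM in this assay, at which 2 of the 3 values shown sit, setting where compound 1 lies, compound 4 is expected to stay near that limit, a step of about a number no higher from compound 1 to compound 4 (the limit leaves the size open).

Compound 4 is therefore estimated at 100000 nM in this assay, within 30000 nM to 300000 nM.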

Compound 4, half-maximal inhibitory concentration: > 100000 nM
Compound 4 was reported as a limit (the forecaster's own chance of this, stated with the estimate: 60%); the middle value sits exactly at the limit.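

Compound 4, like compound 1 and compound 2, gives only a limit, so no new step can be read among these three: the limit of > 100000 nM in this assay, at which 3 of the 4 values shown sit. The compounds shown leave open whether 3-methylphenyl in place of phenyl shifts the number at all, and whether it would do so on compound 3.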